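The source may hold more compounds than are shown below. What is called first, only, known or untested is meant among the compounds shown, and "the series" means these compounds.

Measured so far in an assay on membranes from HeLa cells for displacement of a labelled ligand from adenosine receptor A3 (Homo sapiens), read by scintillation counting, with a stated time of 180 min, tested at 1 uM; a higher number here means more inhibition at the concentration tested (going by the name of the read-out), a lower number less inhibition:
- compound 1 `CC1=C(C(=O)C2CC2)C(c2ccsc2)NC(=O)N1` gives 1%
- compound 2 `CC1=C(C(=O)SC(C)C)C(c2ccsc2)NC(=O)N1` gives 1%
- compound 3 `CC1=C(C(=O)OCC2CC2)C(c2ccco2)NC(=O)N1` gives 1%

Compound 3 stands level with compounds 1 and 2 in this assay; all three sit at the floor of the read-out, within the scatter of one another.

Compound 4 `CC1=C(C(=O)OCC2CC2)C(c2ccsc2)NC(=O)N1` differs from compound 3 by thiophen-3-yl in place of furan-2-yl on a saturated ring carbon.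

For the measured compounds named here, the only measured step, no change at the digits printed from compound 1 to compound 2 (within the scatter), changes the group on the carbonyl carbon, not the saturated ring carbon, so it bears on the present change only in showing that the series has so far been flat. Going by the values given here, compound 1 carries thiophen-3-yl and compound 3 carries furan-2-yl, and their values are indistinguishable, though no single step links them. No step beyond the scatter is expected in this assay: a number 1 percentage points higher from compound 3 to compound 4 (within the scatter).

Compound 4 is therefore estimated at 2%, range -8% to 12%.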

Compound 4, a percentage reported as inhibition, at one concentration (the size of the read-out at that concentration, not a potency): 3%
Beside the measured number, compound 4's estimate is 1 percentage points below it; the range from low to high includes it.
By their numbers in this assay, from the lowest: compounds 1, 2, 3 and 4 (each within the scatter of the next).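

In this assay, for the compounds shown here, thiophen-3-yl in place of furan-2-yl on the saturated ring carbon gives the first direct reading at this position, a number 2 percentage points higher from compound 3 to compound 4 (within the scatter), so this exchange of one five-membered aromatic ring for another does not separate the two compounds. On the carbonyl carbon, cyclopropylmethoxy also reads flat against both other groups, a number 2 percentage points higher from compound 2 to compound 4 (within the scatter) and a number 2 percentage points higher from compound 1 to compound 4 (within the scatter). Nothing available explains these flat readings. As far as these compounds go, whether a carboxylic acid or an aminomethyl group on the saturated ring carbon, or a longer chain on the carbonyl carbon, would lift the read-out remains open.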